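Adding a methoxy group to compound 3

The compounds below may be only part of what the source reports. "The series", "measured", "known", "first", "only" and "open" are said of these compounds alone.

Measured in a functional assay on HeLa cells (Homo sapiens) for antiproliferative activity, with a stated time of 48 h (a higher number here means a weaker inhibitor, a lower number a stronger inhibitor), so far:
Compound 1 `C=C(Br)C(=O)Nc1ccc(C(=O)/C=C/c2cccc(OC)c2OC)cc1` gives 380 nM
Compound 2 `C=C(Br)C(=O)Nc1ccc(C(=O)/C=C/c2ccc(OC)c(OC)c2)cc1` gives 770 nM
Compound 3 `C=C(Br)C(=O)Nc1ccc(C(=O)/C=C/c2ccc(OC)cc2OC)cc1` gives 1100 nM

Compound 3 stands within the usual scatter of compound 2, while compound 1 has a lower number, by a gap beyond the scatter. Compound 4 `C=C(Br)C(=O)Nc1ccc(C(=O)/C=C/c2ccc(OC)c(OC)c2OC)cc1` carries methoxy in place of hydrogen on an aromatic carbon, ortho to two methoxy groups (methoxy in place of hydrogen on an aromatic carbon). Among the measured compounds shown here, no measured pair differs in one place, so the expectation rests on the three values alone, which reach down to compound 1 (380 nM). A modest step to a lower number in this assay is expected, possibly none beyond the scatter. The estimate amounts to a 1.8-fold lower number from compound 3 to compound 4 (0.26 log units; within the scatter) as the expected step. Compound 4 is estimated at 600 nM with 220 nM to 1600 nM as its expected range.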

Compound 4, half-maximal inhibitory concentration: 510 nM
Beside the measured number, compound 4's estimate is 1.2-fold (0.07 log units) above it; the measured number falls inside the stated range.
By their numbers in this assay, from the lowest: compounds 1, 4, 2 and 3 (each within the scatter of the next, the first and the last beyond it).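

In this assay methoxy in place of hydrogen on an aromatic carbon, ortho to two methoxy groups, gives a 2.2-fold lower number from compound 3 to compound 4 (0.33 log units; beyond the scatter) and so moves the number beyond the scatter from one starting compound. The same change gives a 1.5-fold lower number from compound 2 to compound 4 (0.18 log units; within the scatter) and a 1.3-fold higher number from compound 1 to compound 4 (0.13 log units; within the scatter) in the other two readings, both within the scatter, so the size of the step depends on the compound it is read from. Nothing available here accounts for this difference. As far as these compounds go, whether a hydroxyl, an amine or an ethoxy group at this place would give a step like that of methoxy remains open.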